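This account rests on a few compounds, and the source may have more. Where it says the series, first, only, none or still open, it means among the compounds named here.

Measured so far in a functional assay on PC-3 cells (Homo sapiens) for antiproliferative activity, read by MTT assay, with a stated time of 24 h; a lower number here means a stronger inhibitor, a higher number a weaker inhibitor:
- compound 1 `CCn1c(C(=O)N[C@@H](C)C(=O)OC)ccc1C(CC)(CC)c1ccc(OCS(=O)(=O)c2ccccc2)c(C)c1` gives > 50000 nM
- compound 2 `CCn1c(C(=O)NC(C)(C)CO)ccc1C(CC)(CC)c1ccc(OCS(=O)(=O)c2ccccc2)c(C)c1` gives 9850 nM
- compound 3 `CCn1c(C(=O)N[C@H](C)C(=O)O)ccc1C(CC)(CC)c1ccc(OCS(=O)(=O)c2ccccc2)c(C)c1` gives 20100 nM

Compound 1 stands at the edge of what this assay reports: its value is a limit, not a number (the limit of > 50000 nM in this assay, at which 1 of the 3 values shown sits). Compound 2 and compound 3 both give actual numbers, so the steps from compound 1 are lower bounds: an at least 5.0-fold lower number from compound 1 to compound 2 (0.70 log units; beyond the scatter) and an at least 2.4-fold lower number from compound 1 to compound 3 (0.39 log units; beyond the scatter). Between the two measured numbers, a 2.0-fold higher number from compound 2 to compound 3 (0.31 log units; beyond the scatter).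

Compound 4 `CCn1c(C(=O)NC2(C(=O)O)CC2)ccc1C(CC)(CC)c1ccc(OCS(=O)(=O)c2ccccc2)c(C)c1` differs from compound 1 in one place: 1-carboxycyclopropyl in place of 1-(methoxycarbonyl)ethyl on an amide-type nitrogen. The step that bears most directly on this change is the one from the ester to the acid on the same amide-type nitrogen, an at least 2.4-fold lower number from compound 1 to compound 3 (0.39 log units; beyond the scatter); compound 4 carries a 1-carboxycyclopropyl group in the same position, so a lower number than compound 1 is expected, of a size close to that of compound 3. The modest step of a 2.0-fold higher number from compound 2 to compound 3 (0.31 log units; beyond the scatter) sets where the acid sits relative to compound 2. Compound 4 is therefore estimated at 20000 nM, within 8000 nM to 50000 nM, meaning an expected at least 2.5-fold lower number from compound 1 to compound 4 (0.39 log units; beyond the scatter).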

Compound 4, half-maximal inhibitory concentration: 26300 nM
The estimate for compound 4 lay 1.3-fold (0.12 log units) below the measured number, within the range that was stated.
By their numbers in this assay, from the lowest: compound 2; then compounds 3 and 4 (each within the scatter of the next). At a limit, above all of these: compound 1.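

In this assay, the new acid cannot be told apart from the earlier one: 1-carboxycyclopropyl in place of 1-carboxyethyl on the amide-type nitrogen gives a 1.3-fold higher number from compound 3 to compound 4 (0.12 log units; within the scatter), so the ring in this group leaves the reading unchanged within the scatter. Both acids read weaker than the 1-(hydroxymethyl)-1-methylethyl group, with a 2.0-fold higher number from compound 2 to compound 3 (0.31 log units; beyond the scatter) now joined by a 2.7-fold higher number from compound 2 to compound 4 (0.43 log units; beyond the scatter). The comparison with the methyl ester stays only a floor, an at least 1.9-fold lower number from compound 1 to compound 4 (0.27 log units; that floor lies within the scatter), because compound 1 sits at a limit of the assay and not at a number: the limit of > 50000 nM in this assay, at which 1 of the 4 values shown sits.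

Still open, from the compounds shown here alone, is how a 1-(methoxycarbonyl)cyclopropyl group would read, which would show the ring carrying a methyl ester rather than an acid. A 1-carboxycyclobutyl group or an amine at this nitrogen also remains untested among the compounds shown here.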